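The source may hold more compounds than are shown below. What is called first, only, known or untested is meant among the compounds shown, and "the series" means these compounds.

Two measured analogues share one core. Compound 1 `COc1ccc(Cc2cnc(CCc3ccc(-c4ccccc4C(=O)O)cc3)[nH]2)cc1` gives 513 nM in an in vitro functional assay on cells for agonist activity at Bombesin receptor subtype-3 (Mus musculus), read by luminescence and calcium flux; on this read-out lower numbers stand for an effect already at smaller amounts and higher numbers for an effect only at larger amounts of compound. Compound 2 `Cc1ccc(Cc2cnc(CCc3ccc(-c4ccccc4C(=O)O)cc3)[nH]2)cc1` gives 162 nM in this assay, the lowest of the two numbers. The step is a 3.2-fold lower number from compound 1 to compound 2 (0.50 log units; beyond the scatter). Compound 3 `O=C(O)c1ccccc1-c1ccc(CCc2ncc(CC3CCCCCC3)[nH]2)cc1` carries cycloheptyl in place of 4-methylphenyl on a saturated chain carbon bound to an aromatic carbon. Among the measured compounds shown here, the single measured step concerns methoxy against methyl on the group that is now replaced altogether, so it bears on the new step only loosely; no step beyond the scatter is expected in this assay, giving a 1.0-fold lower number from compound 2 to compound 3 (0.01 log units; within the scatter). Compound 3 is therefore estimated at 160 nM, within 40 nM to 650 nM.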

Compound 3, half-maximal effective concentration: 5.7 nM
Estimate against measurement, compound 3: 28-fold (1.45 log units) above; measured number outside the range, below it.
By their numbers in this assay, from the lowest: compound 3; then compound 2; then compound 1.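

At this position, on a saturated chain carbon bound to an aromatic carbon, replacing the aromatic ring itself has a large effect in this assay: cycloheptyl in place of 4-methylphenyl gives a 28-fold lower number from compound 2 to compound 3 (1.45 log units; beyond the scatter) and cycloheptyl in place of 4-methoxyphenyl gives a 90-fold lower number from compound 1 to compound 3 (1.95 log units; beyond the scatter) on the same core. The earlier step changed only a substituent on the phenyl ring, whereas here a non-aromatic ring of carbon only enters with the heavy-atom number unchanged. No available evidence bears on the reason for this result. Open questions are whether cyclohexyl, cyclopentyl or an open hexyl chain would hold the low number, and how an amine on the cycloheptyl ring would fare.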